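The source may report more compounds than this note shows. Statements on the series, on what has been measured and on what is new or still open speak of the compounds shown alone.

Measured so far in an ADME assay on microsomes from liver (Homo sapiens) for metabolic stability, read by LC-MS, using NADPH, tested at 5 uM; on this read-out higher numbers stand for a longer-lived compound and lower numbers for a shorter-lived compound:

Compound 1, `NS(=O)(=O)c1cc(-c2nnc(CCl)o2)c(Cl)cc1SCc1ccccc1`, gives 0.235 h.
Compound 2, `NS(=O)(=O)c1cc(-c2nnc(Cn3cc(-c4ccccc4)nn3)o2)c(Cl)cc1SCc1ccccc1`, gives 0.21 h.
Compound 3, `NS(=O)(=O)c1cc(-c2nnc(CNC(=O)c3ccccc3)o2)c(Cl)cc1SCc1ccccc1`, gives 0.187 h.

Compound 3 sits within the scatter of both other numbers in this assay: the step of a 1.1-fold lower number from compound 2 to compound 3 (0.05 log units; within the scatter) and the step of a 1.3-fold lower number from compound 1 to compound 3 (0.10 log units; within the scatter) are both small, and so is a 1.1-fold lower number from compound 1 to compound 2 (0.05 log units; within the scatter). On these three compounds the half-life has not moved beyond the usual variation whatever group sits on the saturated chain carbon bound to the aromatic carbon.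

Compound 4, `NS(=O)(=O)c1cc(-c2nnc(/C=C/c3cccc(Cl)c3)o2)c(Cl)cc1SCc1ccccc1`, is not yet measured. It differs from compound 3 by 2-(3-chlorophenyl)ethenyl in place of benzamidomethyl on an aromatic carbon. For the measured compounds named here, none of the measured steps makes exactly this exchange: the three measured steps all swap the group on the saturated chain carbon, whereas here the whole benzamidomethyl leaves and a 2-(3-chlorophenyl)ethenyl enters on the aromatic carbon of the five-membered ring. What the measured steps do show is that changing the group at this end of the shared core has left this assay flat. On that basis, the step from compound 3 to compound 4 is expected to be a 1.1-fold higher number from compound 3 to compound 4 (0.03 log units; within the scatter), that is, no change beyond the scatter in either direction. Compound 4 is therefore estimated at 0.2 h in this assay, with a range from 0.1 h to 0.4 h.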

Compound 4, half-life: 0.352 h
Compound 4: middle estimate off by 1.8-fold (0.25 log units), on the low side; the range from low to high includes it.
By their numbers in this assay, from the lowest: compounds 3, 2, 1 and 4 (each within the scatter of the next).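

For the compounds shown here, compound 4 is the first in the set in which the group on the aromatic carbon of the five-membered ring does not start with a saturated chain carbon, and the half-life in this assay still does not leave the usual variation (a 1.9-fold higher number from compound 3 to compound 4 (0.27 log units; within the scatter); a 1.7-fold higher number from compound 2 to compound 4 (0.22 log units; within the scatter); a 1.5-fold higher number from compound 1 to compound 4 (0.18 log units; within the scatter)). The flat picture therefore extends past exchanges on the saturated chain carbon to replacement of the whole group, including the loss of the 1 hydrogen-bond donor and 1 hydrogen-bond acceptor of benzamidomethyl and the entry of a chlorine-bearing 2-(3-chlorophenyl)ethenyl. Across these four compounds, no exchange at this position has yet produced a step beyond the scatter, and nothing available here bears on why.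

The compounds shown leave open whether a primary amine, a carboxylic acid or a longer saturated chain on this aromatic carbon would move the half-life beyond the scatter, and whether 2-phenylethenyl without the chlorine would behave like compound 4. As far as these compounds go, all four compounds also keep the rest of the shared core unchanged, so the effect of any exchange elsewhere on it remains unknown.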